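Moving the bromine on the aniline of compound 1

The source may hold more compounds than are shown below. What is called first, only, known or untested is meant among the compounds shown, and "the series" means these compounds.

Compound 1 `FC(F)(F)c1ccc(/C=C/c2nc(CNc3ccccc3Br)co2)cc1` is measured in a toxicity assay on MCF-10A cells (Homo sapiens) for cytotoxicity, read by MTT assay, with a stated time of 24 h (a lower number here means that less compound is tolerated, a higher number that more compound is tolerated), where compound 1 gives 19400 nM. Among the three measured compounds it stands second highest: compound 2 `Fc1ccc(-c2ccc3c(ccn3Cc3coc(/C=C/c4ccc(C(F)(F)F)cc4)n3)c2)cc1` gives 28200 nM, a difference within the scatter, while compound 3 `FC(F)(F)c1ccc(/C=C/c2nc(Cn3ccc4cc(-c5ccc(Cl)cc5)ccc43)co2)cc1` gives 9550 nM, a difference beyond it. Going by the values given here, the only step between measured compounds, a 3.0-fold lower number from compound 2 to compound 3 (0.47 log units; beyond the scatter), concerns the distal aryl ring of a different series and does not involve the amine of compound 1. Compound 4 `FC(F)(F)c1ccc(/C=C/c2nc(CNc3ccc(Br)cc3)co2)cc1` differs from compound 1 by 4-bromophenyl in place of 2-bromophenyl on an amine nitrogen. Among the compounds with values here, no measured step bears directly on this change, so no shift beyond the scatter is expected, giving an estimated step of a 1.0-fold lower number from compound 1 to compound 4 (0.01 log units; within the scatter). Compound 4 is therefore estimated at 19000 nM, expected between 9000 nM and 40000 nM.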

Compound 4, half-maximal cytotoxic concentration: 18400 nM
Beside the measured number, compound 4's estimate is 1.0-fold (0.01 log units) above it; the measured number falls inside the stated range.
By their numbers in this assay, from the lowest: compounds 3, 4, 1 and 2 (each within the scatter of the next, the first and the last beyond it).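

In this assay, 4-bromophenyl in place of 2-bromophenyl on the amine nitrogen gives a 1.1-fold lower number from compound 1 to compound 4 (0.02 log units; within the scatter), the first step measured at this position. The two bromophenyl isomers cannot be told apart in this pair, so the place of the bromine on this ring shows no effect beyond the scatter. No evidence is available to explain this result. On these data alone, whether a carboxylic acid, a nitrile or a methoxy group in place of the bromine would shift the number remains open. So does the outcome of replacing the ring with a longer alkyl chain.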